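This account rests on a few compounds, and the source may have more. Where it says the series, first, only, none or still open, it means among the compounds named here.

Compound 1 `CC(=O)ONC(=O)/C=C/c1ccccc1OC(=O)c1ccccc1`: 30200 nM
Compound 2 `O=C(/C=C/c1ccccc1O)NO`: 55200 nM

In a functional assay on A549 cells (Homo sapiens) for inhibition, read by ELISA, with a stated time of 24 h (on this read-out lower numbers stand for stronger inhibition of growth and higher numbers for weaker inhibition of growth), compound 2 gives 55200 nM, the highest of the two numbers shown, while compound 1 gives 30200 nM, a gap that lies within the scatter, so the two cannot be told apart. Compound 3 `COc1ccccc1/C=C/C(=O)NO` has not been measured. It differs from compound 2 by one change: methyl in place of hydrogen on an oxygen on an aromatic ring. Within the data shown here, no measured pair shows this change, so nothing here indicates its size or direction. The estimated step of a 1.2-fold lower number from compound 2 to compound 3 (0.09 log units; within the scatter) is expected to be none beyond the scatter. Compound 3 is therefore expected to give about 45000 nM, within a range from 15000 nM to 150000 nM.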

Compound 3, concentration for 50% growth inhibition: 53500 nM
Compound 3: the middle estimate sits 1.2-fold (0.08 log units) below what was measured; low and high end bracket the measured number.
By their numbers in this assay, from the lowest: compounds 1, 3 and 2 (each within the scatter of the next).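

In this assay the step of a 1.0-fold lower number from compound 2 to compound 3 (0.01 log units; within the scatter) gives the first measured size for methyl in place of hydrogen on an oxygen on an aromatic ring. Going from hydroxy to methoxy at this position therefore leaves the growth-inhibition number within the scatter, so the hydrogen on this oxygen can give way to a methyl without a detectable shift here. Nothing available accounts for this result.

On these data alone, whether a longer chain such as ethyl on this oxygen, or an amine in place of the hydroxy group, would also leave the number within the scatter stays open. This single pair also cannot show whether the change behaves the same way on other cores.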